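The compounds below may be only part of what the source reports. "The series", "measured", "known", "first", "only" and "open" are said of these compounds alone.

Working notes on the series. Going by the values given here, compound 1 `COc1ccccc1S(=O)(=O)/C=C/c1ccccn1`, compound 2 `COc1ccccc1S(=O)(=O)/C=C/c1ncccc1Cl` and compound 3 `COc1ccccc1S(=O)(=O)/C=C/c1cccnc1Cl` are the three members measured so far, and all three sit at the inactive end of the read-out. In an ADME assay on BV-2 cells (Mus musculus) for cytotoxicity, with a stated time of 24 h, tested at 10 uM (on this read-out lower numbers stand for a stronger effect and higher numbers for a weaker effect at the one concentration tested), compound 1 gives 100%. Compound 2 gives 100% in this assay. Compound 3 gives 99.7% in this assay, the lowest of the three numbers, though its distance to compound 1 and to compound 2 lies within the scatter, so no order among the three can be read from it.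

Among the compounds with values here, the one paired step available is no change at the digits printed from compound 1 to compound 2 (within the scatter), the change being (chloro in place of hydrogen on an aromatic carbon). How the core of compound 3 differs from the core of compound 1 is not broken down here.

Compound 4 `COc1ccccc1S(=O)(=O)/C=C/c1ccc(Cl)nc1Cl` has not yet been measured in this assay. It differs from compound 3 by chloro in place of hydrogen on an aromatic carbon. This is the same kind of change as from compound 1 to compound 2, not the same change: in compound 2 the chloro enters ortho to a large group, two atoms from the ring nitrogen, whereas in compound 4 it enters next to the ring nitrogen, meta to a chloro group and para to a large group.

Given that the step from compound 1 to compound 2 was flat, the expected step in this assay from compound 3 to compound 4 is a number 0.7 percentage points lower from compound 3 to compound 4 (within the scatter), likewise within the scatter. Compound 4 is therefore estimated at 99% in this assay. For compound 4 the expected range runs from 88% to 100%.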

Compound 4, a percentage reported as activity, at one concentration (the size of the read-out at that concentration, not a potency): 100%
For compound 4 the middle estimate is 1 percentage points below the measured one; low and high end bracket the measured number.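

In this assay the new step is a number 0.3 percentage points higher from compound 3 to compound 4 (within the scatter), and it sits beside the earlier chloro in place of hydrogen step without a readable difference: the same change on two cores in this assay, no change at the digits printed (within the scatter) from compound 1 to compound 2 and a number 0.3 percentage points higher (within the scatter) from compound 3 to compound 4, 0.3 percentage points apart, within the scatter of two such steps. For these two pairs, then, the change behaves alike on both cores, and adding a chloro group leaves the compounds at the inactive end of the read-out, at the one concentration tested. This does not show that the change would carry over to a core where the read-out has room to move, as both steps start from values at the inactive end, where a flat step cannot separate a transferable effect from no effect at all; the two pairs also place the chloro group differently on the ring, so neither the core nor the place is tested on its own.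

The compounds shown leave open whether any substituent on this ring moves the number in this assay, as only hydrogen and chloro appear there, and an amine, a carboxylic acid or a longer chain could behave differently. Also open, on these data alone, is how far the flat picture holds at other concentrations or exposure times.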